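Methanesulfonamido in place of trifluoromethyl: what compound 4 might give

The source may hold more compounds than are shown below. What is called first, only, known or untested is meant among the compounds shown, and "the series" means these compounds.

Compound 1 `CC(=O)Nc1ccc(S(=O)(=O)Nc2cccc(-c3nc(-c4ccc(NC(=O)c5cccnc5)cc4Cl)no3)c2)cc1Cl`: > 10000 nM
Compound 2 `O=C(Nc1cccc(-c2nc(-c3ccc(NC(=O)c4cccnc4)cc3Cl)no2)c1)Nc1cccc(C(F)(F)F)c1`: 1900 nM
Compound 3 `O=C(Nc1cccc(-c2nc(-c3ccc(NC(=O)c4cccnc4)cc3Cl)no2)c1)Nc1cc(C(F)(F)F)cc(C(F)(F)F)c1`: 1900 nM

In a functional assay on MDA-MB-231 cells (Homo sapiens) for antiproliferative activity, read by MTT assay, with a stated time of 72 h (on this read-out lower numbers stand for stronger inhibition and higher numbers for weaker inhibition), compound 1 reaches only a limit, > 10000 nM, and the reading is that (the limit of > 10000 nM in this assay, at which 1 of the 3 values shown sits). For the measured compounds named here, compound 2, in this assay, gives 1900 nM and stands level with compound 3, which gives 1900 nM; the one measured step, no change at the digits printed from compound 2 to compound 3 (within the scatter), shows that a second trifluoromethyl on that ring left the value where it was.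

Compound 4 `CS(=O)(=O)Nc1cccc(NC(=O)Nc2cccc(-c3nc(-c4ccc(NC(=O)c5cccnc5)cc4Cl)no3)c2)c1` differs from compound 2 by methanesulfonamido in place of trifluoromethyl on an aromatic carbon. Going by the values given here, no measured step exchanges trifluoromethyl for methanesulfonamido, so the only step that bears on this change is the one from compound 2 to compound 3, and it lies within the scatter. The shared core of compound 2 and compound 4 carries the rest unchanged. On that basis the step in this assay from compound 2 to compound 4 is expected to be small, with no clear direction, and the estimate is a 1.3-fold higher number from compound 2 to compound 4 (0.12 log units; within the scatter). For compound 4 the expected value in this assay is 2500 nM, within a range from 800 nM to 8000 nM.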

Compound 4, half-maximal inhibitory concentration: > 10000 nM
Compound 4 was reported as a limit (the forecaster's own chance of this, stated with the estimate: 15%); middle value at least 4.0-fold (0.60 log units) away from the limit.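

In this assay, for the compounds shown here, this is the first change on the outer ring of the urea that moves the read-out beyond the scatter: an at least 5.2-fold higher number from compound 2 to compound 4 (0.72 log units; beyond the scatter). The earlier step, no change at the digits printed from compound 2 to compound 3 (within the scatter), showed only that a second trifluoromethyl left the value where it was, so it gave no sign that this ring could lose activity; the position meta to a large group now proves sensitive to which group it carries, with methanesulfonamido failing to stand in for trifluoromethyl. In this assay compound 4 gives > 10000 nM, which is a limit and not a number, so the step has a lower bound but no known size: the limit of > 10000 nM in this assay, at which 2 of the 4 values shown sit.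

The compounds shown leave open which part of methanesulfonamido carries the loss, as the one exchange brings in the sulfonyl and the amide-like hydrogen together, and a methyl sulfone or an N-methyl methanesulfonamido group at this position would separate the two. They also leave open whether an amine, a carboxylic acid or a plain methoxy group here would stay near compound 2 or fall to the same limit.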